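A few compounds are considered here, and "the series" means these few. Any claim that something is new, unique, unknown or untested is made for them only; others in the source may bear on it.

Measured so far:
- compound 1, `COc1cc(C2=NN(C(C)=O)C(c3cc(Cl)cc(Cl)c3)O2)cc(OC)c1OC`: 93.9%
- compound 2, `COc1ccc(OC)c(/C=N/NC(=O)c2cc(OC)c(OC)c(OC)c2)c1`: 51.7%

Of the compounds shown here, two have been tested in a functional assay on PC-3 cells (Homo sapiens) for antiproliferative activity, read by MTT assay, tested at 5 uM; a higher number here means a stronger effect of the compound at the concentration tested, a lower number a weaker effect. Compound 1 gives 93.9%, the higher of the two numbers. Its nearest neighbour on this scale is compound 2 with 51.7%, a gap that lies beyond the usual scatter of repeated measurements. For the measured compounds named here, no pair of these two differs in only one place, so nothing is known about how a single change moves the number.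

Compound 3, `COc1cc(C2=NN(C(C)=O)C(c3ccccc3F)O2)cc(OC)c1OC`, has not yet been measured in this assay. It shares the core of compound 1 and differs from it in one place:

2-fluorophenyl in place of 3,5-dichlorophenyl on a saturated ring carbon

Going by the values given here, nothing measured so far tells how a change at this saturated ring carbon affects the read-out. With compound 1 near the top of the scale, the step is expected to be downward rather than upward, but of moderate size: the expected step from compound 1 to compound 3 is a number 23.9 percentage points lower from compound 1 to compound 3 (beyond the scatter). For compound 3 the estimate in this assay is 70%, within a range from 40% to 92%.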

Compound 3, a percentage reported as inhibition, at one concentration (the size of the read-out at that concentration, not a potency): 31.6%
For compound 3 the middle estimate is 38.4 percentage points above the measured one; measured number outside the range, below it.
By their numbers in this assay, from the lowest: compound 3; then compound 2; then compound 1.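

In this assay, the group on this saturated ring carbon turns out to matter a great deal: with the rest of the core of compound 1 unchanged, putting 2-fluorophenyl in place of 3,5-dichlorophenyl gives a number 62.3 percentage points lower from compound 1 to compound 3 (beyond the scatter). For the compounds shown here, the high number of compound 1 therefore does not come from the shared core alone, and this is the first single change in the set to show that. The two groups both hold one six-membered aromatic ring of carbon only, with no hydrogen-bond donors or acceptors and no net charge, yet nothing measured here explains why the swap costs so much.

This one step changes the kind of halogen, how many there are and where they sit on the phenyl ring all at once, so it cannot say which of these matters; 3,5-difluorophenyl or 2-chlorophenyl at this carbon would begin to pull them apart. Also open, as far as these compounds go, is how this position responds to something other than a halogen-bearing phenyl ring, such as a phenyl ring carrying an amine or a carboxylic acid.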